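This account rests on a few compounds, and the source may have more. Where it says the series, first, only, none or still open, it means among the compounds named here.

The measured compounds and their values:

compound 1 `CCC(C(=O)N1CCN(c2ccccc2)CC1)N1C(=O)CCC1=O`, 0%
compound 2 `CC(C(=O)N1CCN(c2ccc(Cl)cc2)CC1)N1C(=O)CCC1=O`, 0%
compound 3 `CCC(C(=O)N1CCN(c2cccc(C(F)(F)F)c2)CC1)N1C(=O)CCC1=O`, 0%

All three were tested in a functional assay on the whole organism (strain Swiss) with Mus musculus as the target, in the maximal electroshock model, with a stated time of 1 h, at a dose of 100 mg/kg by the intraperitoneal route; on this read-out higher numbers stand for a stronger effect at the one dose given and lower numbers for a weaker effect. Compound 2 gives 0%, which puts it level with compound 1 and compound 3 at the digits shown; none of the three shows any effect in this assay. Within the data shown here, the only single-point step among them, no change at the digits printed from compound 1 to compound 3 (within the scatter), is a change on the aromatic ring that leaves the read-out where it was.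

Compound 4 `Cc1cccc(N2CCN(C(=O)C(C)N3C(=O)CCC3=O)CC2)c1` differs from compound 2 in one place: 3-methylphenyl in place of 4-chlorophenyl on an amine nitrogen in a ring. Among the measured compounds shown here, no measured step exchanges 4-chlorophenyl for 3-methylphenyl on that ring nitrogen, so the closest guide is the step from compound 1 to compound 3, which also alters the substituent on the phenyl ring and produced no change. Since compounds 1, 2 and 3 all sit at the same inactive level in this assay, the step to compound 4 is expected to stay within the scatter, no change at the digits printed from compound 2 to compound 4 (within the scatter). Compound 4 is therefore estimated to give 0% in this assay, with a range from 0% to 10%.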

Compound 4, a percentage reported as activity, at one dose (the size of the read-out at that dose, not a potency): 0%
Beside the measured number, compound 4's estimate shows no gap at the digits printed, within the range that was stated.
By their numbers in this assay, from the lowest: compounds 1, 2, 3 and 4 (each within the scatter of the next).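

In this assay, the outcome of 3-methylphenyl in place of 4-chlorophenyl on an amine nitrogen in a ring is no change at the digits printed from compound 2 to compound 4 (within the scatter). This extends the picture at this position: exchanging one substituted phenyl for another, and not only adding trifluoromethyl to a bare phenyl, leaves the read-out at the same level, though with all four compounds at the bottom of the scale the step cannot rank the two groups. Nothing measured here speaks to the reason for this result.

From the compounds shown here alone, whether any group on that ring nitrogen can lift the read-out stays open, for instance an amine or a carboxylic acid in place of the phenyl ring. Also open, going by these compounds, is whether a longer chain on the ring atom that bears the amide carbonyl would do so.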